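The compounds below may be only part of what the source reports. "The series", "measured", "known", "first", "only" and "open" are said of these compounds alone.

Measured compounds:
- compound 1, `CN(C)CC(O)CON`: > 50000 nM
- compound 2, `CC(C)NCC(O)CON`: 66000 nM
- compound 3, `C=CCNCC(O)CON`: 21000 nM

In an assay for inhibition of Ornithine decarboxylase (Rattus norvegicus) (on this read-out higher numbers stand for weaker inhibition and lower numbers for stronger inhibition), compound 1 gives only a limit, > 50000 nM, and no number. Compound 2 gives 66000 nM and compound 3 gives 21000 nM, the lowest of the two numbers in this assay; its nearest neighbour is compound 2, reached by the step of a 3.1-fold lower number from compound 2 to compound 3 (0.50 log units; beyond the scatter). That step is the only one measured on the amine substituent of the shared core.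

Compound 4, `C#CCNCC(O)CON`, differs from compound 3 by ethynyl in place of vinyl on a saturated chain carbon bound to an amine nitrogen. Among the measured compounds shown here, no measured step covers this change itself; the step of a 3.1-fold lower number from compound 2 to compound 3 (0.50 log units; beyond the scatter) shows that changing the substituent on the amine nitrogen moved this assay modestly, so a step of similar size, in either direction, is the most that the data support. The step from compound 3 to compound 4 is expected to be a 1.4-fold lower number from compound 3 to compound 4 (0.15 log units; within the scatter). Compound 4 is therefore estimated at 15000 nM in this assay, with a range from 5000 nM to 45000 nM.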

Compound 4, half-maximal inhibitory concentration: 8400 nM
For compound 4 the middle estimate is 1.8-fold (0.25 log units) above the measured one, within the range that was stated.
By their numbers in this assay, from the lowest: compound 4; then compound 3; then compound 2.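

With ethynyl in place of vinyl on a saturated chain carbon bound to an amine nitrogen, this assay shows a 2.5-fold lower number from compound 3 to compound 4 (0.40 log units; beyond the scatter), so swapping a double bond for a triple bond at an unchanged count of heavy atoms is enough to move the number beyond the scatter. Among the compounds shown here, measured against the isopropyl group, the propargyl group gives a 7.9-fold lower number from compound 2 to compound 4 (0.90 log units; beyond the scatter), which spans all the numbers so far. Among the compounds with numbers, the order from the lowest runs compound 4, compound 3, compound 2, and none of these three goes against it.

Compound 1 gives only a limit and stays outside this order: the limit of > 50000 nM in this assay, at which 1 of the 4 values shown sits. As far as these compounds go, whether a longer chain carrying a triple bond, such as butynyl, or a benzyl group on the amine nitrogen would extend this order remains open.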